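Phenyl in place of ethyl: a lower tolerated concentration expected

The compounds below may be only part of what the source reports. "The series", "measured", "known", "first", "only" and "open" are said of these compounds alone.

In an ADME assay on RAW264.7 cells (Mus musculus) for cytotoxicity, read by MTT assay, with a stated time of 24 h (a lower number here means that less compound is tolerated, a higher number that more compound is tolerated), two compounds with a shared core have been measured. Compound 1 `CC/C=C\C[C@H]1C(=O)C=C[C@H]1CC(=O)OCC` gives 146 uM, while compound 2 `CC/C=C\C[C@H]1C(=O)C=C[C@H]1CC(=O)OC(C)CC` gives 53 uM, the lower of the two numbers. Going by the values given here, the only measured step is a 2.8-fold lower number from compound 1 to compound 2 (0.44 log units; beyond the scatter), which is modest but beyond the scatter. It places ethyl in place of hydrogen on a saturated chain carbon bound to an oxygen next to a carbonyl group and a saturated chain carbon.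

Compound 3 `CC/C=C\C[C@H]1C(=O)C=C[C@H]1CC(=O)OC(C)c1ccccc1` changes the same carbon again, with phenyl in place of ethyl on a saturated chain carbon bound to an oxygen next to a carbonyl group and a saturated chain carbon. Among the compounds with values here, no measured compound carries phenyl here, so the evidence is thin. Within the data shown here, the single guide is the earlier change at this carbon, a 2.8-fold lower number from compound 1 to compound 2 (0.44 log units; beyond the scatter), and it points downward. A further fall in this assay is therefore expected, though smaller than that step, and no change beyond the scatter remains possible. The expected result is a 1.8-fold lower number from compound 2 to compound 3 (0.25 log units; within the scatter). For compound 3 the estimated value is 30 uM, with an expected range from 10 uM to 75 uM.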

Compound 3, half-maximal toxic concentration: 31 uM
The estimate for compound 3 lay 1.0-fold (0.01 log units) below the measured number, and the stated range covers the measured number.
By their numbers in this assay, from the lowest: compounds 3 and 2 (each within the scatter of the next); then compound 1.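

In this assay, phenyl in place of ethyl on this saturated chain carbon gives a 1.7-fold lower number from compound 2 to compound 3 (0.23 log units; within the scatter) and so stays within the scatter, which means that compound 2 and compound 3 cannot be told apart here, even though the entering phenyl brings a six-membered aromatic ring and more heavy atoms than the ethyl it replaces. Phenyl in place of hydrogen at the same carbon gives a 4.7-fold lower number from compound 1 to compound 3 (0.67 log units; beyond the scatter) and lies beyond the scatter, so two different groups at this carbon now each stand apart from compound 1, where earlier only ethyl did. No measurement shown here offers an explanation for this result.

The compounds shown leave open whether other groups at this carbon would also stand apart from compound 1 in this assay or remain level with ethyl and phenyl, as a longer chain, an amine or a carboxylic acid might show. They also leave open whether a phenyl ring carrying a fluorine or a methoxy group would keep the number of compound 3 or move away from it.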